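This account rests on a few compounds, and the source may have more. Where it says the series, first, only, none or still open, it means among the compounds named here.

Compound 1 `COc1ccc(-n2nncc2CN2C(=O)C3(C(C#N)=C(N)Oc4c3c3nc5ccccc5nc3c3ccccc43)c3ccccc32)cc1`: in an ADME assay on HUVEC cells (Homo sapiens) for antiproliferative activity, read by MTT assay, with a stated time of 48 h (on this read-out lower numbers stand for stronger inhibition and higher numbers for weaker inhibition), compound 1 gives > 50000 nM, a limit of the assay.
Compound 2 `COc1ccccc1-n1nncc1CN1C(=O)C2(C(C#N)=C(N)Oc3c2c2nc4ccccc4nc2c2ccccc32)c2ccccc21`: in this assay compound 2 gives > 50000 nM, again a limit.
Compound 3 `CCOc1ccc(-n2nncc2CN2C(=O)C3(C(C#N)=C(N)Oc4c3c3nc5ccccc5nc3c3ccccc43)c3ccccc32)cc1`: in this assay compound 3 gives > 50000 nM, also a limit.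

Compound 3 stands at the limit, and so do both other compounds: the limit of > 50000 nM in this assay, at which 3 of the 3 values shown sit. The steps a step that the two limits leave unreadable from compound 1 to compound 2, a step that the two limits leave unreadable from compound 1 to compound 3 and a step that the two limits leave unreadable from compound 2 to compound 3 therefore stay unreadable. Compound 4 `Cc1cc(C)cc(-n2nncc2CN2C(=O)C3(C(C#N)=C(N)Oc4c3c3nc5ccccc5nc3c3ccccc43)c3ccccc32)c1` differs from compound 3 by 3,5-dimethylphenyl in place of 4-ethoxyphenyl on an aromatic nitrogen. Among the compounds with values here, no measured step on this shared core bears readably on that change, so no step beyond the scatter can be foreseen in this assay; compound 4 is expected to give 60000 nM, between 15000 nM and 200000 nM, and the step that the limit leaves unreadable from compound 3 to compound 4 is an estimate resting only on the limits seen.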

Compound 4, half-maximal inhibitory concentration: > 50000 nM
Compound 4: only a limit was reported (the forecaster's own chance of this, stated with the estimate: 80%); the middle value is on the limit's open side.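

Compound 4 gives no readable step to compound 1, compound 2 or compound 3 in this assay, and the steps among them all stay unreadable: the limit of > 50000 nM in this assay, at which 4 of the 4 values shown sit. What the compounds shown leave open is whether any group on this aromatic nitrogen of the shared core changes activity at all.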